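The source may report more compounds than this note shows. Statements on the series, on what has been measured and on what is new or still open speak of the compounds shown alone.

In an ADME assay on MRC5 cells (Homo sapiens) for cytotoxicity, read by fluorescence and resazurin assay, with a stated time of 24 h (a higher number here means a weaker inhibitor, a lower number a stronger inhibitor), compound 1 (`CCOC(=O)c1c(C(C)C)oc2nc(N3CCCC3)ccc12`) gives > 330000 nM as a limit of the assay, not a number. Compound 2 (`CCOC(=O)c1c(-c2ccccc2)oc2nc(N3CCCC3)ccc12`) gives > 297000 nM as a limit too. For compound 3 (`CC(C)c1oc2nc(N3CCCC3)ccc2c1C(=O)O`) the entry is "not determined" (no result reported) and it adds nothing here. Within the data shown here, the only measured step is a step that the two limits leave unreadable from compound 1 to compound 2 and it involves a different group, so it offers no size to carry over. Compound 4 (`CCCCNc1ccc2c(C(=O)OCC)c(C(C)C)oc2n1`) carries butylamino in place of pyrrolidin-1-yl on an aromatic carbon. Among the measured compounds shown here, no measured step bears on this change, so the expected step in this assay is only small, toward a stronger inhibitor if any (an at least 1.3-fold lower number from compound 1 to compound 4 (0.12 log units; that floor lies within the scatter)). The estimate for compound 4 is 250000 nM (expected range 80000 nM to 400000 nM), and it may well return only a limit.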

Compound 4, half-maximal inhibitory concentration: > 328000 nM
Compound 4 gave a limit, no number; the forecaster's own chance of this, stated with the estimate: 60%; middle value at least 1.3-fold (0.11 log units) away from the limit.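

Among these compounds, compound 1 and compound 4 both gave only limits of the assay rather than numbers, so no step between them can be read. The compounds shown leave open whether butylamino in place of pyrrolidin-1-yl shifts the value at all, or in which direction.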